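Chloro to Trifluoromethyl: An Estimate for Compound 3

The compounds below may be only part of what the source reports. "The series", "measured", "known", "first", "only" and "open" are said of these compounds alone.

Two compounds have been measured in a functional assay on A549 cells (Homo sapiens) for antiproliferative activity, read by MTT assay, with a stated time of 72 h; on this read-out higher numbers stand for weaker inhibition and lower numbers for stronger inhibition:

Compound 1, `NC(=S)N1N=C(c2ccc(N3CCCCC3)cc2)CC1c1ccc(Cl)cc1`: 33800 nM
Compound 2, `Clc1ccc(-c2csc(N3N=C(c4ccc(N5CCCCC5)cc4)CC3c3ccc(Cl)cc3)n2)cc1`: 46400 nM

On the numbers shown, compound 2 and compound 1 sit within the scatter of one another: a 1.4-fold higher number from compound 1 to compound 2 (0.14 log units; within the scatter). Compound 3, `FC(F)(F)c1ccc(-c2csc(N3N=C(c4ccc(N5CCCCC5)cc4)CC3c3ccc(Cl)cc3)n2)cc1`, differs from compound 2 by trifluoromethyl in place of chloro on an aromatic carbon. Among the measured compounds shown here, the only measured step, from compound 1 to compound 2, concerns a different part of the molecule and says nothing about this change. For the measured compounds named here, with no step bearing on it, compound 3 is expected to show no shift beyond the scatter in this assay, a 1.1-fold lower number from compound 2 to compound 3 (0.04 log units; within the scatter). Compound 3 is therefore estimated at 42000 nM, with a range from 15000 nM to 120000 nM.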

Compound 3, half-maximal inhibitory concentration: 42000 nM
Compound 3: the middle estimate sits on the measured number at the digits printed; the measured number falls inside the stated range.
By their numbers in this assay, from the lowest: compounds 1, 3 and 2 (each within the scatter of the next).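

Trifluoromethyl in place of chloro, on an aromatic carbon para to a large group, gives a 1.1-fold lower number from compound 2 to compound 3 (0.04 log units; within the scatter) in this assay. Among the compounds shown here, this is the only measured step at this position, and on it the two groups cannot be told apart, so a larger group of four heavy atoms is accepted there without a shift beyond the scatter. No measurement here explains why the two groups read alike.

Still open, as far as these compounds go, is whether a different kind of group at this position, such as an amine or a carboxylic acid, would shift the number beyond the scatter.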